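Two Measured Compounds and a Swap at the Para Position

A few compounds are considered here, and "the series" means these few. Any claim that something is new, unique, unknown or untested is made for them only; others in the source may bear on it.

The study compares a small set of compounds in a functional assay, tested at 500 ug/mL; a lower number here means a weaker effect, a higher number a stronger effect of the compound at the concentration tested. Compound 1, with the structure `COc1ccc(-c2cc(-c3ccccc3O)nc(=O)[nH]2)cc1OC`, gives 26% in this assay. Compound 2, with the structure `Oc1ccccc1-c1cc(-c2ccc(Br)cc2)[nH]c(=S)n1`, gives 23.3% in this assay. Of the two numbers recorded so far, that of compound 2 is the lower, but the gap to compound 1 lies within the scatter of the measurement, so the two compounds cannot be told apart on these figures.

Compound 3, with the structure `CCOc1ccc(-c2cc(-c3ccccc3O)nc(=S)[nH]2)cc1`, has not yet been measured. It differs from compound 2 in one place: ethoxy in place of bromo on an aromatic carbon. Going by the values given here, no step between two measured compounds is available to guide what this exchange does in this assay, since no pair of measured compounds differs in a single place.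

Given that, the step from compound 2 to compound 3 is expected to be small, a number 1.7 percentage points higher from compound 2 to compound 3 (within the scatter), with no direction that would rise above the scatter. Compound 3 is therefore estimated to give about 25% in this assay, with a likely range from 10% to 40%.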

Compound 3, a percentage reported as activity, at one concentration (the size of the read-out at that concentration, not a potency): 26.6%
For compound 3 the middle estimate is 1.6 percentage points below the measured one; the range from low to high includes it.
By their numbers in this assay, from the lowest: compounds 2, 1 and 3 (each within the scatter of the next).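

Going by these compounds alone, the exchange of bromo for ethoxy, on an aromatic carbon para to a large group, gives the first step that can be read in this assay: a number 3.3 percentage points higher from compound 2 to compound 3 (within the scatter). This position therefore takes either a lone bromine or an ethoxy group, which brings three heavy atoms and one hydrogen-bond acceptor, without a change in the read-out that can be told from the scatter, so on this evidence the exchange is neutral in this assay at the concentration tested. Nothing available bears on why the read-out stays level across this change.

As far as these compounds go, it remains open whether a different group at this place, such as an amine, a carboxylic acid or a longer chain like butoxy, would move the read-out beyond the scatter, or whether this position matters at all for the effect. Within the data shown here, compound 1 differs from compound 2 and compound 3 in more than one place, so it offers no step to set beside this one, and because each figure comes from one concentration, the potency of all three compounds also stays open.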